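Phenyl in place of pyrazin-2-yl on a carbonyl carbon

This account rests on a few compounds, and the source may have more. Where it says the series, first, only, none or still open, it means among the compounds named here.

Measured in a functional assay on KBVIN cells (Homo sapiens) for antiproliferative activity, read by sulforhodamine B assay, with a stated time of 3 days; a lower number here means a stronger inhibitor of growth, a higher number a weaker inhibitor of growth:
- compound 1 `COc1ccc(N2CCN(C)CC2)cc1Nc1ncc(F)c(Nc2ccc(F)cc2)n1` gives 910 nM
- compound 2 `O=C(Nc1cccc(Nc2ncc(F)c(Nc3ccc(F)cc3)n2)c1)c1cnccn1` gives 20100 nM
- compound 3 `CN(C)c1ccc(C(=O)Nc2cccc(Nc3ncc(F)c(Nc4ccc(F)cc4)n3)c2)cc1` gives > 10000 nM, which is a limit and not a number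

Of the two numerical values, compound 2 at 20100 nM is the higher. Compound 1 at 910 nM is lower, and the gap lies beyond the scatter. The third entry is a limit: the limit of > 10000 nM in this assay, at which 1 of the 3 values shown sits.

The next comparison is compound 4 `O=C(Nc1cccc(Nc2ncc(F)c(Nc3ccc(F)cc3)n2)c1)c1ccccc1` against compound 2. The difference is phenyl in place of pyrazin-2-yl on a carbonyl carbon.

For the measured compounds named here, only one measured step changes the group at this place, a step that the limit leaves unreadable from compound 2 to compound 3, and it gives no size to carry over. In this assay the expectation therefore rests on compound 2 at 20100 nM, with no shift in either direction beyond the scatter expected. A result reported only as a limit would also not be surprising. The estimated change is a 1.3-fold lower number from compound 2 to compound 4 (0.13 log units; within the scatter), an expected step that stays within the scatter. For compound 4 the expected value is 15000 nM, with an estimated range of 6000 nM to 40000 nM.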

Compound 4, concentration for 50% growth inhibition: > 10000 nM
Compound 4 gave a limit, no number (the forecaster's own chance of this, stated with the estimate: 40%); the middle value is on the limit's open side.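

In this assay compound 4 gives > 10000 nM which is a limit and not a number. For the compounds shown here, no step from compound 2 or compound 3 to compound 4 can be read: the limit of > 10000 nM in this assay, at which 2 of the 4 values shown sit. The compounds shown leave open whether phenyl in place of pyrazin-2-yl on a carbonyl carbon changes growth inhibition at all, and by how much.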